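The compounds below may be only part of what the source reports. "The series", "measured", "known", "first", "only" and "open" are said of these compounds alone.

Compound 1 `CCCOC(=O)C1=C(C)NC(=O)NC1c1ccoc1`: 50%
Compound 2 `CCCOC(=O)C1=C(C)NC(=O)NC1c1ccsc1`: 44%
Compound 3 `CCCOC(=O)C1=C(C)N(C)C(=O)NC1c1ccoc1`: 1%

In an assay on membranes from CHO cells for displacement of a labelled ligand from adenosine receptor A1 (Homo sapiens), read by scintillation counting, with a stated time of 60 min, tested at 1 uM (a lower number here means less inhibition, a higher number more inhibition at the concentration tested (going by the name of the read-out)), compound 1 gives the highest of the three numbers. Compound 2 sits close to it, a number 6 percentage points lower from compound 1 to compound 2 (within the scatter), while compound 3 lies far below, a number 49 percentage points lower from compound 1 to compound 3 (beyond the scatter). Compound 4 `CC1=C(C(=O)NC(C)C)C(c2ccoc2)NC(=O)N1` differs from compound 1 in one place: isopropylamino in place of propoxy on a carbonyl carbon. Neither measured step touches this part of the shared core: one swaps thiophen-3-yl for furan-3-yl on a saturated ring carbon, the other puts methyl in place of hydrogen on an amide-type nitrogen in a ring. The measured steps give no direct guide, so the direction of this change in this assay is open. Compound 4 is expected to give 35%, within 10% to 60%. The step from compound 1 to compound 4 is thus estimated as a number 15 percentage points lower from compound 1 to compound 4 (beyond the scatter), a modest fall.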

Compound 4, a percentage reported as inhibition, at one concentration (the size of the read-out at that concentration, not a potency): 1%
For compound 4 the middle estimate is 34 percentage points above the measured one; the measured number lies below the stated range.
By their numbers in this assay, from the lowest: compounds 3 and 4 (each within the scatter of the next); then compounds 2 and 1 (each within the scatter of the next).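

Within the data shown here, at the carbonyl carbon, isopropylamino in place of propoxy gives a number 49 percentage points lower from compound 1 to compound 4 (beyond the scatter) in this assay and so shows that this part of the molecule, untouched by the earlier steps, strongly affects the read-out. The change leaves the number of heavy atoms the same, yet it swaps an oxygen for a nitrogen and adds a hydrogen-bond donor.

On these data alone, whether the nitrogen or the branched chain matters more stays open; a straight propylamino group would help separate the two. Nothing available explains the fall.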